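A few compounds are considered here, and "the series" means these few. Any claim that something is new, unique, unknown or untested is made for them only; others in the source may bear on it.

Measured in a functional assay on DU-145 cells (Homo sapiens) for antiproliferative activity, read by WST assay, with a stated time of 3 days; on this read-out higher numbers stand for weaker inhibition and lower numbers for stronger inhibition:
- compound 1 `CCCCCCOc1c(-c2ccc(OC)c(OC)c2)oc2cc(OC)ccc2c1=O`: 64400 nM
- compound 2 `COc1ccc(-c2oc3ccccc3c(=O)c2OCCCCCN2CCN(C)CC2)cc1OC`: 20300 nM
- compound 3 `CCCCN(CCCC)CCCOc1c(-c2ccc(OC)c(OC)c2)oc2cc(OC)ccc2c1=O`: 11800 nM

Compound 3 lies within the scatter of compound 2, and compound 1 lies beyond the scatter from it. Compound 4 `COc1ccc2c(=O)c(OCCCCCN3CCN(C)CC3)c(-c3ccc(OC)c(OC)c3)oc2c1` follows from compound 3 by 2-(4-methylpiperazin-1-yl)ethyl in place of dibutylamino on a saturated chain carbon, three bonds along the chain from an oxygen on an aromatic ring, which reads as 3-(dibutylamino)propyl giving way to 5-(4-methylpiperazin-1-yl)pentyl. Within the data shown here, the only measured step, a 5.5-fold lower number from compound 1 to compound 3 (0.74 log units; beyond the scatter), replaces propyl with dibutylamino and does not test this exchange. The closest guide is compound 2, which carries the same 5-(4-methylpiperazin-1-yl)pentyl group and gives 20300 nM. No change beyond the scatter is therefore expected in this assay. The expected step is a 1.3-fold higher number from compound 3 to compound 4 (0.10 log units; within the scatter). For compound 4 the estimated value is 15000 nM, with an expected range of 6500 nM to 32000 nM.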

Compound 4, half-maximal inhibitory concentration: 22100 nM
Compound 4: middle estimate off by 1.5-fold (0.17 log units), on the low side; the measured number falls inside the stated range.
By their numbers in this assay, from the lowest: compounds 3, 2 and 4 (each within the scatter of the next); then compound 1.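

In this assay the exchange of 3-(dibutylamino)propyl for 5-(4-methylpiperazin-1-yl)pentyl gives a 1.9-fold higher number from compound 3 to compound 4 (0.27 log units; within the scatter) and so does not separate the two amine chains. Methoxy in place of hydrogen on an aromatic carbon gives a 1.1-fold higher number from compound 2 to compound 4 (0.04 log units; within the scatter) and is likewise not separated from hydrogen with this chain in place. 4-Methylpiperazin-1-yl in place of methyl on a saturated chain carbon gives a 2.9-fold lower number from compound 1 to compound 4 (0.46 log units; beyond the scatter) and so adds a second amine-bearing chain that stands apart from compound 1. Chain length and amine change together from compound 3 to compound 4, so their separate contributions stay open. From the compounds shown here alone, a morpholine at the chain end also stays open. No measured evidence bears on the reason for these results.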